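This account rests on a few compounds, and the source may have more. Where it says the series, first, only, none or still open, it means among the compounds named here.

Measured compounds:
- compound 1 `O=C(Nc1ccc([N+](=O)[O-])cc1)c1c(O)c2cccnc2n(-c2ccccc2)c1=O`: -7.6%
- compound 2 `Nc1ccc(NC(=O)c2c(O)c3cccnc3n(-c3ccccc3)c2=O)cc1`: -5.5%
- compound 3 `O=C(NCc1cccnc1)c1c(O)c2cccnc2n(-c2ccccc2)c1=O`: 25.5%

In a functional assay on the whole organism for inhibition, with Rattus norvegicus as the target, read by paw edema, at a dose of 100 mg/kg by the oral route (a higher number here means more inhibition at the dose given (going by the name of the read-out), a lower number less inhibition), compound 3 gives the highest of the three numbers, with a number 31 percentage points higher from compound 2 to compound 3 (beyond the scatter) and a number 33.1 percentage points higher from compound 1 to compound 3 (beyond the scatter), both beyond the scatter. Compound 4 `COc1ccc(NC(=O)c2c(O)c3cccnc3n(-c3ccccc3)c2=O)cn1` differs from compound 3 in one place: 6-methoxypyridin-3-yl in place of (pyridin-3-yl)methyl on an amide-type nitrogen. The two steps that bear on this are those to compound 3, since both replace a ring joined directly to the amide-type nitrogen by the (pyridin-3-yl)methyl group, each time with a large gain; compound 4 moves back to a ring joined directly to that nitrogen. A drop in this assay of roughly a number 17.5 percentage points lower from compound 3 to compound 4 (beyond the scatter) is therefore expected, though the new ring is not the same as either earlier one. Compound 4 is estimated at 8%, within -10% to 28%.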

Compound 4, a percentage reported as inhibition, in the whole organism at one dose (the size of the read-out at that dose, not a potency): 13.1%
Beside the measured number, compound 4's estimate is 5.1 percentage points below it, and the stated range covers the measured number.
By their numbers in this assay, from the lowest: compounds 1 and 2 (each within the scatter of the next); then compound 4; then compound 3.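

In this assay a ring joined directly to the amide-type nitrogen need not stay at the low end: 6-methoxypyridin-3-yl brings a number 18.6 percentage points higher from compound 2 to compound 4 (beyond the scatter) and a number 20.7 percentage points higher from compound 1 to compound 4 (beyond the scatter) against the two earlier directly joined rings. Yet it does not match (pyridin-3-yl)methyl, with a number 12.4 percentage points lower from compound 3 to compound 4 (beyond the scatter) on this change. Nothing measured here explains either direction. Still open, from the compounds shown here alone, is whether the methoxy group or the direct joining to the nitrogen sets that drop: plain pyridin-3-yl on the same nitrogen, or (6-methoxypyridin-3-yl)methyl, would separate the two.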